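This account rests on a few compounds, and the source may have more. Where it says the series, first, only, none or still open, it means among the compounds named here.

Among the measured compounds shown here, compound 3 `CC(C(=O)NCc1ccc(C(F)(F)F)nc1N1CCC(c2ccccc2)CC1)c1ccc(NS(C)(=O)=O)c(F)c1` stands second highest of the three numbers so far in a functional assay on CHO-K1 cells for antagonist activity at transient receptor potential cation channel subfamily V member 1 (Homo sapiens), read by FLIPR; a higher number here means a weaker inhibitor, a lower number a stronger inhibitor. Its nearest neighbour is compound 2 `CC(C(=O)NCc1ccc(C(F)(F)F)nc1N1CCC(C)(C)CC1)c1ccc(NS(C)(=O)=O)c(F)c1`, which gives 0.3 nM; compound 3 gives 0.6 nM, a gap within the scatter. The furthest is compound 1 `CC(C(=O)NCc1ccc(C(F)(F)F)nc1NC1CCCCC1)c1ccc(NS(C)(=O)=O)c(F)c1`, which gives 20.4 nM. Compound 4 `Cc1ccc(CC2CCN(c3nc(C(F)(F)F)ccc3CNC(=O)C(C)c3ccc(NS(C)(=O)=O)c(F)c3)CC2)cc1` differs from compound 3 by 4-methylbenzyl in place of phenyl on a saturated ring carbon. Two of the measured steps concern the group on the aromatic carbon as a whole: a 68-fold lower number from compound 1 to compound 2 (1.83 log units; beyond the scatter) and a 34-fold lower number from compound 1 to compound 3 (1.53 log units; beyond the scatter), both large, but both exchange the cyclohexylamino for a piperidinyl group and so do not speak to a change kept within the piperidine. The step that bears directly on the substituent on the saturated ring carbon is a 2.0-fold higher number from compound 2 to compound 3 (0.30 log units; within the scatter), which stayed within the scatter. Compound 4 is therefore expected to show no step beyond the scatter in this assay, a 1.2-fold higher number from compound 3 to compound 4 (0.07 log units; within the scatter). The estimate for compound 4 is 0.7 nM, with a range from 0.2 nM to 2.5 nM.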

Compound 4, inhibition constant: 0.2 nM
Compound 4: middle estimate off by 3.5-fold (0.54 log units), on the high side, and the stated range covers the measured number.
By their numbers in this assay, from the lowest: compounds 4, 2 and 3 (each within the scatter of the next, the first and the last beyond it); then compound 1.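

In this assay, the saturated ring carbon three ring bonds from the ring nitrogen now shows a change beyond the scatter: 4-methylbenzyl in place of phenyl gives a 3.0-fold lower number from compound 3 to compound 4 (0.48 log units; beyond the scatter), a modest step. Among the compounds shown here, the earlier change at this carbon, a 2.0-fold higher number from compound 2 to compound 3 (0.30 log units; within the scatter), had stayed within the scatter, so this is the first sign that the group held there can move the number, and the longer 4-methylbenzyl group costs nothing in inhibition. Nothing available explains this step.

The compounds shown leave open whether the methylene link or the ring methyl carries the step, which plain benzyl or 4-methylphenyl at this carbon would separate. Also open, going by these compounds, is how an amine or a carboxylic acid on the benzyl ring would read in this assay.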